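The source may report more compounds than this note shows. Statements on the series, on what has been measured and on what is new or still open speak of the compounds shown alone.

Notes on the selenium-containing nucleoside series, cytotoxicity only.

Compound 1 `OC[C@H]1O[C@@H](n2cnc3c(O)ncnc32)C[Se]1` is the parent. In a functional assay on PBM cells (Homo sapiens) for cytotoxicity (a higher number here means a weaker inhibitor, a lower number a stronger inhibitor), compound 1 gives > 100000 nM, which is a limit of the assay and not a number. Compound 2 `Nc1nc(O)c2ncn([C@H]3C[Se][C@@H](CO)O3)c2n1` carries an amino group on the core. In this assay compound 2 gives > 100000 nM, again a limit. Compound 3 `OC[C@H]1O[C@H](n2cnc3c(O)ncnc32)C[Se]1` shares all atoms and bonds with compound 1 and differs only in configuration as drawn. In this assay compound 3 gives > 100000 nM, also a limit.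

The two measured steps are therefore a step that the two limits leave unreadable from compound 1 to compound 2 and a step that the two limits leave unreadable from compound 1 to compound 3. Both are unreadable in size because of the limit of > 100000 nM in this assay, at which 3 of the 3 values shown sit; the second is a pure configurational step because of the fact that compounds 1 and 3 differ only in the configuration as drawn.

Compound 4 `Nc1nc(O)c2ncn([C@@H]3C[Se][C@@H](CO)O3)c2n1` is the next member to be measured in this assay. Relative to compound 3 the change is amino in place of hydrogen on an aromatic carbon. For the measured compounds named here, the step that bears most directly on it is the one from compound 1 to compound 2, the same amino-for-hydrogen exchange on the other configuration, and it gave no readable size. Going by the values given here, no step in this set moves any compound off the limit.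

Compound 4 is therefore expected to remain at or near the limit, with the step that the limit leaves unreadable from compound 3 to compound 4 expected to be nothing beyond the scatter. The estimate for compound 4 in this assay is 150000 nM, within 50000 nM to 500000 nM.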

Compound 4, half-maximal inhibitory concentration: > 100000 nM
Compound 4: only a limit was reported (the forecaster's own chance of this, stated with the estimate: 90%); the middle value lies beyond the limit too.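

In this assay compound 4 gives > 100000 nM which is a limit of the assay and not a number. The steps to compound 4 from compound 2 and compound 3 therefore cannot be read in size. The compounds shown leave open whether the amino group or the configuration has any effect in this assay on cytotoxicity.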